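The source may report more compounds than this note shows. Statements on the series, on what has been measured and on what is new or still open speak of the compounds shown alone.

Three compounds share one core: compound 1 is `C#CCSc1nnc(CC)n1N1C(=O)c2ccccc2C1=O`, compound 2 is `CCc1nnc(SCC(=O)c2ccccc2)n1N1C(=O)c2ccccc2C1=O` and compound 3 is `CCc1nnc(SCC(=O)c2ccc(Cl)cc2)n1N1C(=O)c2ccccc2C1=O`. In a functional assay on A549 cells (Homo sapiens) for cytotoxicity, read by MTT assay, with a stated time of 48 h (on this read-out higher numbers stand for weaker inhibition and lower numbers for stronger inhibition), compound 1 gives only a limit, > 200000 nM. Compound 2 likewise gives only a limit in this assay, > 200000 nM. Compound 3 also gives only a limit in this assay, > 200000 nM, so compound 3 stands on no number at all. The steps a step that the two limits leave unreadable from compound 1 to compound 2, a step that the two limits leave unreadable from compound 1 to compound 3 and a step that the two limits leave unreadable from compound 2 to compound 3 stay unreadable because of the limit of > 200000 nM in this assay, at which 3 of the 3 values shown sit. Compound 4 is `CCc1nnc(SCC(=O)c2ccc(C)cc2)n1N1C(=O)c2ccccc2C1=O`; it differs from compound 3 in one place: methyl in place of chloro on an aromatic carbon. Within the data shown here, no measured step reads, so no step size beyond the scatter can be expected in this assay. Compound 4 is therefore expected at 200000 nM, between 60000 nM and 600000 nM. The estimated step of a number no higher from compound 3 to compound 4 (the limit leaves the size open) is expected to stay within the scatter.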

Compound 4, half-maximal inhibitory concentration: > 200000 nM
Compound 4: only a limit was reported; the forecaster's own chance of this, stated with the estimate: 85%; the middle value sits exactly at the limit.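

In this assay compound 4 also gives only a limit, > 200000 nM. Its steps from compound 1, compound 2 and compound 3 therefore cannot be read: the limit of > 200000 nM in this assay, at which 4 of the 4 values shown sit.

The compounds shown leave open how large any of these steps is, and which change to the shared core, if any, would give a number in this assay.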